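A few compounds are considered here, and "the series" means these few. Any claim that something is new, unique, unknown or untested is made for them only; others in the source may bear on it.

Compound 2 `CNC(=O)c1cccn(Cc2ccccc2)c1=O` is the only one of the three measured compounds for which a physicochemical assay for solubility (on this read-out lower numbers stand for lower solubility and higher numbers for higher solubility), reports a number rather than a limit: in this assay compound 2 gives 78 ug/mL. Compound 1 `CNC(=O)c1cc(C(=O)NC2CCC2)cn(Cc2cccnc2)c1=O` reaches >= 99 ug/mL in this assay, which is a limit of the assay, (the limit of >= 99 ug/mL in this assay, at which 1 of the 3 values shown sits). Compound 3 `CNC(=O)c1cc(C(=O)NC2CC2)cn([C@H](C)c2ccccc2)c1=O` gives >= 168 ug/mL in this assay, likewise a limit, (the limit of >= 168 ug/mL in this assay, at which 1 of the 3 values shown sits). Compound 4 `CNC(=O)c1cc(C(=O)NC(C)C)cn(Cc2ccccc2)c1=O` differs from compound 2 by isopropylcarbamoyl in place of hydrogen on an aromatic carbon. For the measured compounds named here, no pair of measured compounds differs in one place, so the size of this step is uncertain; since compounds 1 and 3 both sit at limits of this assay, a modest step upward, possibly beyond the scatter, is expected. Compound 4 is expected to give 100 ug/mL, between 40 ug/mL and 250 ug/mL, a step of a 1.3-fold higher number from compound 2 to compound 4 (0.11 log units; within the scatter).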

Compound 4, solubility: >= 136 ug/mL
Compound 4 was reported as a limit; the forecaster's own chance of this, stated with the estimate: 40%; at least 1.3-fold (0.13 log units) between middle value and limit.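

Isopropylcarbamoyl in place of hydrogen on this aromatic carbon, two atoms from the ring nitrogen, gives in this assay an at least 1.7-fold higher number from compound 2 to compound 4 (0.24 log units; that floor lies within the scatter). For the compounds shown here, this is the first step at this position that can be read, and it shows no fall in the read-out on adding the group. Compound 4 sits at a limit of the assay, so only a floor for the step is known and its true size is not.

As far as these compounds go, how far compound 4 lies beyond that limit stays open. Also open, from the compounds shown here alone, is whether a longer chain, an amine or a carboxylic acid in place of isopropylcarbamoyl on this carbon would give a number rather than a limit.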